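Thiazolyl for oxanyl on the amine nitrogen: working notes

This account rests on a few compounds, and the source may have more. Where it says the series, first, only, none or still open, it means among the compounds named here.

In an ADME assay on A549 cells (Homo sapiens) for cytotoxicity, read by CellTiter-Glo (a higher number here means that more compound is tolerated, a lower number that less compound is tolerated), compound 1 `Cc1c(Cc2ccccc2)c(=O)oc2cc(OCC(O)CNCCCCCCO)ccc12` gives 40300 nM and compound 2 `Cc1c(Cc2ccccc2)c(=O)oc2cc(OCC(O)CNC3CCOCC3)ccc12` gives 38200 nM. Compound 2 therefore stands level with compound 1, the two values lying within the scatter of each other. The next compound to be read is compound 3 `Cc1c(Cc2ccccc2)c(=O)oc2cc(OCC(O)CNc3nccs3)ccc12`, which has 1,3-thiazol-2-yl in place of oxan-4-yl on an amine nitrogen.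

Among the measured compounds shown here, only one measured step bears on this change: a 1.1-fold lower number from compound 1 to compound 2 (0.02 log units; within the scatter). It swaps oxan-4-yl for 6-hydroxyhexyl at the same amine nitrogen and stays within the scatter. So far, this position has shown no sensitivity in this assay, but the evidence is a single pair, and neither compound carries a five-membered aromatic ring there. No step beyond the scatter is therefore expected, though the range is kept wide and the direction is only weakly held. The expected step is a 1.3-fold lower number from compound 2 to compound 3 (0.10 log units; within the scatter). For compound 3 the estimated value is 30000 nM, with an expected range of 13000 nM to 60000 nM.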

Compound 3, half-maximal cytotoxic concentration: 93000 nM
Beside the measured number, compound 3's estimate is 3.1-fold (0.49 log units) below it, and the stated range ends below it.
By their numbers in this assay, from the lowest: compounds 2 and 1 (each within the scatter of the next); then compound 3.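

In this assay, among the compounds shown here, the group on the amine nitrogen now matters: 1,3-thiazol-2-yl in place of oxan-4-yl gives a 2.4-fold higher number from compound 2 to compound 3 (0.39 log units; beyond the scatter) and 1,3-thiazol-2-yl in place of 6-hydroxyhexyl gives a 2.3-fold higher number from compound 1 to compound 3 (0.36 log units; beyond the scatter), both modest steps beyond the scatter, whereas the one earlier step at this position stayed within it. The open 6-hydroxyhexyl chain and the six-membered non-aromatic oxan-4-yl ring stand level, and among these three compounds only the five-membered aromatic ring shifts the reading, towards more compound being tolerated. Nothing measured here accounts for the step.

As far as these compounds go, whether the higher number belongs to 1,3-thiazol-2-yl itself or to aromatic rings on this nitrogen more widely remains open, and a phenyl, a pyridin-2-yl or a 1,3-oxazol-2-yl group at the same place would separate these readings. Also open, from the compounds shown here alone, is how the number responds to a methyl or a carboxylic acid on the thiazole ring.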